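A Cyclohexyl Group on the Shared Core

A few compounds are considered here, and "the series" means these few. Any claim that something is new, unique, unknown or untested is made for them only; others in the source may bear on it.

In a functional assay on BT-474 cells (Homo sapiens) for inhibition, read by MTT assay, with a stated time of 5 days (on this read-out lower numbers stand for stronger inhibition and higher numbers for weaker inhibition), compound 1 (`Cc1cc(Nc2nc(NCc3ccccc3F)nc3[nH]ncc23)n[nH]1`) gives 13200 nM and compound 2 (`Cc1cc(Nc2nc(NCc3ccccc3Br)nc3[nH]ncc23)n[nH]1`) gives 10100 nM while compound 3 (`Cc1cc(Nc2nc(NCc3ccc(F)cc3F)nc3[nH]ncc23)n[nH]1`) gives 3220 nM as the lowest number of the three. Bromo in place of fluoro (a 1.3-fold lower number from compound 1 to compound 2 (0.12 log units; within the scatter)) is a small step. The two steps that end at compound 3 (a 4.1-fold lower number from compound 1 to compound 3 (0.61 log units; beyond the scatter) and a 3.1-fold lower number from compound 2 to compound 3 (0.50 log units; beyond the scatter)) are modest. Compound 4 (`Cc1cc(Nc2nc(NCc3ccc(F)cc3F)nc3c2cnn3C2CCCCC2)n[nH]1`) has cyclohexyl in place of hydrogen on an aromatic nitrogen. Going by the values given here, none of the measured steps alters that nitrogen, so they offer only a rough guide to size. For compound 4 a modest step toward a lower number is expected (a 1.8-fold lower number from compound 3 to compound 4 (0.25 log units; within the scatter)) with wide uncertainty. In this assay the estimate for compound 4 is 1800 nM (expected range 300 nM to 12000 nM).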

Compound 4, half-maximal inhibitory concentration: 6230 nM
Compound 4: middle estimate off by 3.5-fold (0.54 log units), on the low side, and the stated range covers the measured number.
By their numbers in this assay, from the lowest: compounds 3, 4, 2 and 1 (each within the scatter of the next, the first and the last beyond it).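

Cyclohexyl in place of hydrogen on an aromatic nitrogen is the first change at this position, and in this assay it gives a 1.9-fold higher number from compound 3 to compound 4 (0.29 log units; within the scatter). Even this large added ring therefore leaves compound 4 indistinguishable from compound 3 in this read-out, whereas the earlier steps to compound 3 changed only the phenyl ring. No evidence shown gives a reason for this result.

As far as these compounds go, it remains open whether a methyl group or a piperidinyl ring carrying an amine on that nitrogen would move the number beyond the scatter. From the compounds shown here alone, whether cyclohexyl would behave the same way alongside the 2-bromophenyl group of compound 2 is also open.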